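A few compounds are considered here, and "the series" means these few. Any claim that something is new, unique, unknown or untested is made for them only; others in the source may bear on it.

Compound 1: `Cc1cccc(CN2CCC=C(CCC(=O)NO)C2=O)c1` in a functional assay on HCT-15 cells (Homo sapiens) for inhibition, read by sulforhodamine B assay (on this read-out lower numbers stand for stronger inhibition of growth and higher numbers for weaker inhibition of growth), gives > 10000 nM, a limit of the assay rather than a number.
Compound 2: `O=C(CCC1=CCCN(Cc2ccc(F)cc2)C1=O)NO` in this assay gives 9960 nM.
Compound 3: `O=C(CCC1=CCCN(CCCc2ccc3ccccc3c2)C1=O)NO` in this assay gives 530 nM.

Among the two compounds with a numerical result, compound 2 stands at the higher number, and the gap to compound 3 lies beyond the scatter of the assay. Among the compounds with values here, the only measured step that changes the group on the saturated chain carbon bound to the ring nitrogen, a number no higher from compound 1 to compound 2 (the limit leaves the size open), starts from a limit and so its size cannot be read; it is bounded because of the limit of > 10000 nM in this assay, at which 1 of the 3 values shown sits, which is where the value of compound 1 sits.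

The unmeasured compound 4, `O=C(CCC1=CCCN(Cc2ccc([N+](=O)[O-])cc2)C1=O)NO`, differs from compound 2 by nitro in place of fluoro on an aromatic carbon. Within the data shown here, no measured step shows what exchanging one substituent for another on that aromatic ring does, so the expectation rests on compound 2 alone, whose 9960 nM gives the starting point. The expected step, a 1.2-fold lower number from compound 2 to compound 4 (0.10 log units; within the scatter), is estimated to lie within the scatter. Compound 4 is therefore expected to give about 8000 nM, with a range from 2500 nM to 25000 nM in this assay.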

Compound 4, concentration for 50% growth inhibition: > 10000 nM
Compound 4: only a limit was reported (the forecaster's own chance of this, stated with the estimate: 35%); at least 1.2-fold (0.09 log units) between middle value and limit.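

In this assay compound 4 gives > 10000 nM, a limit of the assay and not a number. Within the data shown here, this is the only measured exchange on the aromatic carbon para to a large group, and it shows that nitro in place of fluoro at this position brings no gain in growth inhibition, the result being a number no lower from compound 2 to compound 4 (the limit leaves the size open). How large the change is cannot be read, so it remains unknown whether nitro and fluoro differ here at all, because the upper end of the assay is reached: the limit of > 10000 nM in this assay, at which 2 of the 4 values shown sit.

The compounds shown leave open whether any other group on that aromatic carbon, such as an amine or a methoxy group, would give a clearly lower number than the fluoro group of compound 2 does. They also leave open whether the exchange of fluoro for nitro could be read on a compound with a longer chain on the ring nitrogen, where the starting number would lie further from the limit.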